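Shortening the ether chain on compound 2

A few compounds are considered here, and "the series" means these few. Any claim that something is new, unique, unknown or untested is made for them only; others in the source may bear on it.

Of the compounds shown here, two have been measured so far. Compound 1 `C[S+]([O-])/C=C/c1cc(=O)c2ccccc2o1` carries hydrogen on the aromatic carbon where compound 2 `CC(C)CCOc1ccc2oc(/C=C/[S+](C)[O-])cc(=O)c2c1` carries isopentyloxy. In a functional assay on DLD-1 cells (Homo sapiens) for cytotoxicity, with a stated time of 48 h (on this read-out higher numbers stand for weaker inhibition and lower numbers for stronger inhibition), compound 1 gives 8000 nM, and in the same assay compound 2 gives 4100 nM. Of these two numbers, compound 2 has the lower one, but the gap to compound 1, a 2.0-fold lower number from compound 1 to compound 2 (0.29 log units; within the scatter), lies within the scatter, so the two cannot be told apart.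

Compound 3 `CC(C)Oc1ccc2oc(/C=C/[S+](C)[O-])cc(=O)c2c1` differs from compound 2 in one place: isopropyl in place of isopentyl on an oxygen on an aromatic ring. Within the data shown here, the only measured step that bears on this position is a 2.0-fold lower number from compound 1 to compound 2 (0.29 log units; within the scatter), which came from putting the whole isopentyloxy group onto the core and still stayed within the scatter. Trimming that chain to isopropyl on the same oxygen is therefore expected to move the number little, with no step beyond the scatter in either direction. Compound 3 is estimated at 5000 nM, with a range from 2500 nM to 10000 nM, which corresponds to an expected step of a 1.2-fold higher number from compound 2 to compound 3 (0.09 log units; within the scatter).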

Compound 3, half-maximal inhibitory concentration: 8000 nM
For compound 3 the middle estimate is 1.6-fold (0.20 log units) below the measured one; the range from low to high includes it.
By their numbers in this assay, from the lowest: compounds 2, 1 and 3 (each within the scatter of the next).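

In this assay, the second ether on this aromatic carbon gives the same reading as the first: trimming isopentyl to isopropyl on the oxygen leaves the number within the scatter (a 2.0-fold higher number from compound 2 to compound 3 (0.29 log units; within the scatter)), and isopropoxy in place of hydrogen also stays within it (no change at the digits printed from compound 1 to compound 3 (within the scatter)). Hydrogen, isopropoxy and isopentyloxy at this position therefore lie within the scatter of one another, so these three compounds show no readable effect of either adding an ether or changing the length of its chain. No independent measurement is available here to explain these numbers.

On these data alone, what remains open is whether a group of another kind on this oxygen, such as an amine or a carboxylic acid at the end of the chain, or a much longer chain such as decyl, would give a step beyond the scatter. As far as these compounds go, it is also open whether isopropoxy and isopentyloxy would read the same way on a different aromatic carbon of the shared core.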